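This account rests on a few compounds, and the source may have more. Where it says the series, first, only, none or still open, it means among the compounds named here.

Compound 1 `COc1cccc(CNCCCNc2ccnc3cc(C4CCCCC4)ccc23)c1O`: 23 10^-6 cm/s
Compound 2 `COc1ccc(F)cc1CNCCCNc1ccnc2cc(C3CCCCC3)ccc12`: 23 10^-6 cm/s
Compound 3 `COc1ccc(F)cc1CNCCCNc1ccnc2cc(-c3ccc(C(F)(F)F)cc3)ccc12`: 237 10^-6 cm/s

All three compounds were tested in an ADME assay for permeability, using PAMPA, with a stated time of 30 min, at pH 7.4; a higher number here means that the compound crosses the layer faster, a lower number that the compound crosses the layer more slowly. Compound 2 gives 23 10^-6 cm/s in this assay, and compound 1 gives 23 10^-6 cm/s in this assay. The two share one core and differ in one place: 2-hydroxy-3-methoxyphenyl in place of 5-fluoro-2-methoxyphenyl on a saturated chain carbon bound to an amine nitrogen. That change gave no change at the digits printed from compound 2 to compound 1 (within the scatter). Compound 3 gives 237 10^-6 cm/s in this assay and differs from compound 2 in the core itself: 4-(trifluoromethyl)phenyl in place of cyclohexyl on an aromatic carbon. That change gave a 10-fold higher number from compound 2 to compound 3 (1.01 log units; beyond the scatter), and compound 3 stands highest of the three, with both compound 1 and compound 2 well apart from it.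

Compound 4 `COc1cccc(CNCCCNc2ccnc3cc(-c4ccc(C(F)(F)F)cc4)ccc23)c1O` has not yet been measured in this assay. It carries the core of compound 3 and differs from compound 3 in one place: 2-hydroxy-3-methoxyphenyl in place of 5-fluoro-2-methoxyphenyl on a saturated chain carbon bound to an amine nitrogen. The place is described in exactly the same words as for the change from compound 2 to compound 1, so this is the same change, made once on each core. Compound 4 is therefore expected to give a 1.0-fold lower number from compound 3 to compound 4 (0.01 log units; within the scatter) in this assay, a step of about the same size as the earlier one, because no change at the digits printed from compound 2 to compound 1 (within the scatter) stayed within the usual scatter. On that basis compound 4 is estimated to give around 230 10^-6 cm/s in this assay, with a range from 110 10^-6 cm/s to 450 10^-6 cm/s.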

Compound 4, apparent permeability: 237 10^-6 cm/s
Compound 4: the middle estimate sits 1.0-fold (0.01 log units) below what was measured, within the range that was stated.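

In this assay, putting 2-hydroxy-3-methoxyphenyl in place of 5-fluoro-2-methoxyphenyl on the core of compound 3 gave no change at the digits printed from compound 3 to compound 4 (within the scatter), and this matches what the same change did on the other core: the same change on two cores in this assay, no change at the digits printed (within the scatter) from compound 2 to compound 1 and no change at the digits printed (within the scatter) from compound 3 to compound 4, 1.0-fold (0.00 log units) apart, within the scatter of two such steps. Putting 4-(trifluoromethyl)phenyl in place of cyclohexyl gave a 10-fold higher number from compound 1 to compound 4 (1.01 log units; beyond the scatter), and this large step also came out alike with either group on the chain: the same change on two cores in this assay, a 10-fold higher number (1.01 log units; beyond the scatter) from compound 2 to compound 3 and a 10-fold higher number (1.01 log units; beyond the scatter) from compound 1 to compound 4, 1.0-fold (0.00 log units) apart, within the scatter of two such steps. Within these four compounds, each change therefore carried from one core to the other with its size intact, so the two steps could be read separately, but this rests on only one pair of steps per change, in a single assay, and it shows neither why the steps behave this way nor that they would hold on any further core.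

The first change also removes a fluorine and adds a hydroxy group at the same time, so the compounds shown cannot tell what each of these contributes on its own. From the compounds shown here alone, it also remains open whether the two steps would keep their sizes with a nitrile in place of the trifluoromethyl group, or with a longer chain carrying the amine nitrogen.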